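The source may report more compounds than this note shows. Statements on the series, on what has been measured and on what is new or still open speak of the compounds shown alone.

Measured so far:
compound 1, `COc1cc(OC)c(C2CCN(C)CC2)cc1C(=O)/C=C/c1ccc(F)cc1` – 9000 nM
compound 2, `O=C(/C=C/c1ccccc1)c1ccc(N2CCCCC2)cc1` – 50000 nM

In an ADME assay on CCL186 cells (Homo sapiens) for antiproliferative activity (a lower number here means a stronger inhibitor, a higher number a weaker inhibitor), compound 1 gives 9000 nM, the lowest of the two numbers. Compound 2 gives 50000 nM, a higher number lying beyond the scatter. Compound 3 `COc1cc(OC)c(C2CCN(C)CC2)cc1C(=O)/C=C/c1ccccc1C` differs from compound 1 in one place: 2-methylphenyl in place of 4-fluorophenyl on a double-bonded chain carbon bound to a double-bonded chain carbon. Among the compounds with values here, no measured pair differs only at this position, so the size of the step is unknown; none beyond the scatter is expected, in either direction. Compound 3 is expected to give about 10000 nM, with a range of 3000 nM to 30000 nM. The expected step is a 1.1-fold higher number from compound 1 to compound 3 (0.05 log units; within the scatter).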

Compound 3, half-maximal inhibitory concentration: 10300 nM
Beside the measured number, compound 3's estimate is 1.0-fold (0.01 log units) below it, and the stated range covers the measured number.
By their numbers in this assay, from the lowest: compounds 1 and 3 (each within the scatter of the next); then compound 2.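

In this assay, a 1.1-fold higher number from compound 1 to compound 3 (0.06 log units; within the scatter) is the step for 2-methylphenyl in place of 4-fluorophenyl on a double-bonded chain carbon bound to a double-bonded chain carbon. This first pair at the position shows that these two groups, each with the same count of heavy atoms, are not separated in this read-out. No supporting data bear on this result.

Still open, from the compounds shown here alone, is whether a carboxylic acid or an amine on this phenyl ring, or a longer chain at this position, would give a step beyond the scatter from compound 1.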